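Cyclopropyl in Place of Butyl on the Ring Nitrogen

The source may hold more compounds than are shown below. What is called first, only, known or untested is meant among the compounds shown, and "the series" means these compounds.

Measured compounds:
compound 1, `CNc1nc(-c2ccccc2)nc2c1nnn2Cc1ccccc1`: 353 nM
compound 2, `CCCCNc1nc(-c2ccccc2)nc2c1nnn2Cc1ccccc1`: 11 nM
compound 3, `c1ccc(Cn2nnc3c(NC4CC4)nc(-c4ccccc4)nc32)cc1`: not yet measured

In an assay on Cerebral cortex for displacement of a labelled ligand from adenosine receptor A1 (Bos taurus) (a higher number here means a weaker inhibitor, a lower number a stronger inhibitor), compound 2 gives 11 nM, the lowest of the two numbers; compound 1 gives 353 nM, and the step of a 32-fold lower number from compound 1 to compound 2 (1.51 log units; beyond the scatter) is large. Compound 3 differs from compound 2 by cyclopropyl in place of butyl on a nitrogen on an aromatic ring. Going by the values given here, only that one step bears on the change, and it shows that enlarging the group on this nitrogen from hydrogen to butyl lowered the number strongly. Swapping butyl for cyclopropyl is a smaller alteration, so compound 3 is expected to shift modestly toward a higher number, a 2.3-fold higher number from compound 2 to compound 3 (0.36 log units; beyond the scatter). Compound 3 is therefore estimated at 25 nM, within 8 nM to 80 nM.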

Compound 3, inhibition constant: 11.3 nM
For compound 3 the middle estimate is 2.2-fold (0.34 log units) above the measured one; the measured number falls inside the stated range.
By their numbers in this assay, from the lowest: compounds 2 and 3 (each within the scatter of the next); then compound 1.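

In this assay the swap on the nitrogen gives a 1.0-fold higher number from compound 2 to compound 3 (0.01 log units; within the scatter) and so shows that the open butyl chain is not needed for a number of this size. Cyclopropyl, with its three-membered ring, also stands far from methyl, with a 31-fold lower number from compound 1 to compound 3 (1.49 log units; beyond the scatter) as the step between them. Nothing measured here explains why butyl and cyclopropyl read alike.

The compounds shown leave open how cyclobutyl, cyclohexyl or a branched isopropyl group would read on this nitrogen. They also leave open what a hydroxyl or an amine at the end of the butyl chain would do.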